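Trimethoxybenzoate Isomers on a Shared Quinoline Thioether Core

The source may report more compounds than this note shows. Statements on the series, on what has been measured and on what is new or still open speak of the compounds shown alone.

Measured compounds:
compound 1 `COC(=O)/C(=C\c1ccc(OC(=O)c2cc(OC)cc(OC)c2OC)cc1)Sc1ccnc2cc(Cl)ccc12`, 15600 nM
compound 2 `COC(=O)/C(=C\c1ccc(OC(=O)c2cc(OC)c(OC)c(OC)c2)cc1)Sc1ccnc2cc(Cl)ccc12`, 4570 nM

In a functional assay on Jurkat E6.1 cells (Homo sapiens) for cytotoxicity, read by MTT assay, with a stated time of 24 h (a higher number here means a weaker inhibitor, a lower number a stronger inhibitor), compound 2 gives 4570 nM, the lowest of the two numbers measured; the nearest, compound 1, gives 15600 nM. For the measured compounds named here, the only measured step, a 3.4-fold lower number from compound 1 to compound 2 (0.53 log units; beyond the scatter), shows that moving the methoxy groups around the ester-bound ring changes the number beyond the scatter. Compound 3 `COC(=O)/C(=C\c1ccc(OC(=O)c2ccc(OC)c(OC)c2OC)cc1)Sc1ccnc2cc(Cl)ccc12` differs from compound 2 by 2,3,4-trimethoxyphenyl in place of 3,4,5-trimethoxyphenyl on a carbonyl carbon. Going by the values given here, no measured step covers this particular isomer, so the one step available serves only as a guide to the size such a rearrangement can produce. Among the compounds with values here, with the 3,4,5-pattern giving the lowest number so far and the 2,3,5-pattern a higher one, compound 3 is expected to land between them, the estimated step being a 1.8-fold higher number from compound 2 to compound 3 (0.24 log units; within the scatter). Compound 3 is therefore estimated at 8000 nM, within a range from 2500 nM to 25000 nM.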

Compound 3, half-maximal inhibitory concentration: 2410 nM
For compound 3 the middle estimate is 3.3-fold (0.52 log units) above the measured one; measured number outside the range, below it.
By their numbers in this assay, from the lowest: compounds 3 and 2 (each within the scatter of the next); then compound 1.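

In this assay the 2,3,4-trimethoxyphenyl and 3,4,5-trimethoxyphenyl groups on the carbonyl carbon cannot be told apart, as a 1.9-fold lower number from compound 2 to compound 3 (0.28 log units; within the scatter) is a step that leaves the two compounds together. Against the 2,3,5-trimethoxyphenyl group, the new isomer shows a 6.5-fold lower number from compound 1 to compound 3 (0.81 log units; beyond the scatter) as a larger step, so compound 1 now stands apart from both other isomers, with its steps to each printed as beyond the scatter. The data shown offer no measurement that accounts for this separation.

Still open, on these data alone, is what an amine or a carboxylic acid in place of one methoxy group on this ring would give in this assay as a number. Also open is whether an amide in place of the ester link would keep the separation among these three methoxy patterns.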